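This account rests on a few compounds, and the source may have more. Where it says the series, first, only, none or still open, it means among the compounds named here.

For the measured compounds named here, only two compounds have been measured so far in a functional assay on QGY cells (Homo sapiens) for cytotoxicity, read by MTT assay, with a stated time of 48 h; on this read-out higher numbers stand for weaker inhibition and lower numbers for stronger inhibition. Compound 1 `CCOC(=O)[C@@]1(C(=O)Nc2ccccc2Cl)C[C@@H]1c1cc(OC)c(OC)c(OC)c1` reports > 100000 nM, which is a limit of the assay and not a number. Going by the values given here, compound 2 `COc1cc([C@H]2C[C@]2(CO)C(=O)Nc2ccccc2Cl)cc(OC)c1OC` gives 40700 nM, the only exact number available, so it is the single firm reference point.

Compound 3 `COc1cc([C@H]2C[C@@]2(CO)C(=O)Nc2ccccc2Cl)cc(OC)c1OC` is a close relative of compound 2: the two compounds have the same atoms and bonds and differ only in configuration as drawn: 1 of 2 stereo elements differ; a stereocentre at a saturated ring carbon is drawn S in compound 2 and R in compound 3. The two compounds have the same atoms and bonds, and the stereocentre at a saturated ring carbon is drawn S in compound 2 and R in compound 3. Among the compounds with values here, no measured pair shows what such a change does in this assay, so the expectation is cautious: a small shift towards weaker inhibition, possibly none beyond the usual scatter. The expected change is a 1.2-fold higher number from compound 2 to compound 3 (0.09 log units; within the scatter). For compound 3 the estimated value is 50000 nM, with an expected range of 18000 nM to 100000 nM.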

Compound 3, half-maximal inhibitory concentration: > 100000 nM
Compound 3 was reported as a limit; the forecaster's own chance of this, stated with the estimate: 25%; middle value at least 2.0-fold (0.30 log units) from the limit.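

In this assay, changing the drawn configuration at one saturated ring carbon gives an at least 2.4-fold higher number from compound 2 to compound 3 (0.39 log units; beyond the scatter). For the compounds shown here, this is the first sign in these compounds that the spatial arrangement at this carbon matters, and not only which groups are present, because nothing else changes: the fact that compounds 2 and 3 differ only in the configuration as drawn. From the compounds shown here alone, the true size of this step stays unknown, and the step between compound 1 and compound 3 cannot be read, because their values are both limits rather than numbers: the limit of > 100000 nM in this assay, at which 2 of the 3 values shown sit.

Going by these compounds, it remains open whether configuration at this carbon would matter in the same way with ethoxycarbonyl in place of hydroxymethyl. The compounds shown also leave open how a carboxylic acid or an amine in place of hydroxymethyl on this carbon would behave in either configuration.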